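The source may report more compounds than this note shows. Statements on the series, on what has been measured and on what is new or still open speak of the compounds shown alone.

Measured in an ADME assay on L02 cells (Homo sapiens) for cytotoxicity, read by MTT assay, with a stated time of 72 h; a lower number here means a stronger inhibitor, a higher number a weaker inhibitor:
- compound 1 `COc1ccc(/C=C2\CNC/C(=C\c3ccc(OC)c(OC)c3)C2=O)cc1OC`: 15100 nM
- compound 2 `COc1cc(/C=C2\CNC/C(=C\c3cc(OC)c(OC)c(OC)c3)C2=O)cc(OC)c1OC`: 7600 nM
- compound 3 `CCCN1C/C(=C\c2ccc(OC)c(OC)c2)C(=O)/C(=C/c2ccc(OC)c(OC)c2)C1`: 21000 nM

Compound 2, at 7600 nM, lies within the scatter of compound 1 and has a lower number than compound 3.

Compound 4 `CCC(=O)N1C/C(=C\c2cc(OC)c(OC)c(OC)c2)C(=O)/C(=C/c2cc(OC)c(OC)c(OC)c2)C1` has propanoyl in place of hydrogen on an amine nitrogen in a ring of compound 2: propanoyl in place of hydrogen on an amine nitrogen in a ring.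

Within the data shown here, the only measured step at that nitrogen is a 1.4-fold higher number from compound 1 to compound 3 (0.14 log units; within the scatter). Among the measured compounds shown here, it brings in propyl, not propanoyl, and no compound carrying propanoyl has a value yet. As far as these compounds go, no change beyond the scatter is therefore expected in this assay, and the direction stays open.

The expected step is a 1.1-fold higher number from compound 2 to compound 4 (0.02 log units; within the scatter). Compound 4 is estimated at 8000 nM, with an expected range of 2500 nM to 22000 nM.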

Compound 4, half-maximal inhibitory concentration: 4200 nM
Estimate against measurement, compound 4: 1.9-fold (0.28 log units) above, within the range that was stated.
By their numbers in this assay, from the lowest: compounds 4, 2, 1 and 3 (each within the scatter of the next, the first and the last beyond it).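

In this assay, propanoyl on the amine nitrogen in the ring gives a 1.8-fold lower number from compound 2 to compound 4 (0.26 log units; within the scatter). This extends the picture at that nitrogen from propyl, with a 1.4-fold higher number from compound 1 to compound 3 (0.14 log units; within the scatter), to a group carrying a carbonyl, and neither step leaves the scatter. No measurement shown bears on what lies behind either step.

As far as these compounds go, whether propanoyl gives a similar step on the core of compound 1 remains open. So does the outcome at this nitrogen for a longer acyl chain or for a chain ending in an amine or a carboxylic acid.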